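Taking the hydroxy group off compound 3

A few compounds are considered here, and "the series" means these few. Any claim that something is new, unique, unknown or untested is made for them only; others in the source may bear on it.

In an ADME assay on MT4 cells (Homo sapiens) for cytotoxicity, read by MTT assay (on this read-out higher numbers stand for lower toxicity in this test and lower numbers for higher toxicity in this test), three compounds sharing one core have been measured. For compound 1 (`O=C(CSc1nnnn1-c1cccc2ccccc12)N/N=C/c1ccc(Cl)cc1`) the result of > 295000 nM is a limit of the assay and not a number. Compound 2 (`Cc1cccc(/C=N/NC(=O)CSc2nnnn2-c2cccc3ccccc23)c1`) gives 269000 nM in the same test. Compound 3 (`O=C(CSc1nnnn1-c1cccc2ccccc12)N/N=C/c1ccccc1O`) gives 4850 nM and holds the lowest number of the set.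

Compound 4 (`O=C(CSc1nnnn1-c1cccc2ccccc12)N/N=C/c1ccccc1`) differs from compound 3 by a single change (hydrogen in place of hydroxy on an aromatic carbon): hydrogen in place of hydroxy on an aromatic carbon, which turns 2-hydroxyphenyl into phenyl. For the measured compounds named here, two measured steps bear on this, and both are large and beyond the scatter: a 55-fold lower number from compound 2 to compound 3 (1.74 log units; beyond the scatter) and an at least 60-fold lower number from compound 1 to compound 3 (1.78 log units; beyond the scatter) each arrive at the 2-hydroxyphenyl group. Compound 4 lacks the hydroxy, as compound 1 and compound 2 do. Those two carry 4-chlorophenyl and 3-methylphenyl rather than phenyl, which makes the comparison inexact. The step expected in this assay is a 31-fold higher number from compound 3 to compound 4 (1.49 log units; beyond the scatter) and thus large, though perhaps a little smaller than the two measured ones. For compound 4 the estimate is 150000 nM with an expected range from 30000 nM to 300000 nM in this test.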

Compound 4, half-maximal cytotoxic concentration: 216000 nM
The estimate for compound 4 lay 1.4-fold (0.16 log units) below the measured number; measured number inside the range.
By their numbers in this assay, from the lowest: compound 3; then compounds 4 and 2 (each within the scatter of the next). At a limit, above all of these: compound 1.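

Taking the hydroxy group off with nothing else changed gives a 45-fold higher number from compound 3 to compound 4 (1.65 log units; beyond the scatter) in this assay, and since a lower number here means higher toxicity in this test, the higher toxicity of compound 3 can now be tied directly to that one group; the earlier comparisons could only suggest this, as their rings also differed by a methyl or a chloro. The plain phenyl ring of compound 4 also shows that the methyl of compound 2 makes no readable difference, as hydrogen in its place gives a 1.2-fold lower number from compound 2 to compound 4 (0.10 log units; within the scatter). Hydrogen in place of chloro gives an at least 1.3-fold lower number from compound 1 to compound 4 (0.13 log units; that floor lies within the scatter), but the result for compound 1 is a limit of the assay and not a number, so the size of that step cannot be read: the limit of > 295000 nM in this assay, at which 1 of the 4 values shown sits.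

The compounds shown cannot tell whether the low number needs hydroxy itself or would also come with a methoxy or an amine on the same aromatic carbon. They also leave open whether a hydroxy group on another carbon of the ring would give the same result.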